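The compounds below may be only part of what the source reports. "The series", "measured", "known", "first", "only" and "open" are said of these compounds alone.

Measured compounds and their values in the cytotoxicity read-out:
compound 1 `CO[C@@H]1O[C@H](COc2ccc3c(c2)CCCC3)[C@@H](O)[C@H](O)[C@H]1Oc1ccc(OC2CCCCC2)cc1`: 0%
compound 2 `CO[C@H]1O[C@H](COc2ccccc2)[C@@H](O)[C@H](O)[C@H]1Oc1ccc(OC2CCCCC2)cc1`: -11%
compound 3 `CO[C@@H]1O[C@H](COc2ccc(-c3ccccc3)cc2)[C@@H](O)[C@H](O)[C@H]1Oc1ccc(OC2CCCCC2)cc1`: 64%

In a functional assay on MDA-MB-231 cells (Homo sapiens) for cytotoxicity, read by MTT assay, with a stated time of 48 h, tested at 20 uM (a lower number here means less inhibition, a higher number more inhibition at the concentration tested (going by the name of the read-out)), compound 1 gives 0%, the second highest of the three numbers. Compound 2 gives -11% in this assay, and compound 3 gives 64%. Compound 4 `CO[C@@H]1O[C@H](COc2ccccc2)[C@@H](O)[C@H](O)[C@H]1Oc1ccc(OC2CCCCC2)cc1` differs from compound 1 by phenyl in place of 1,2,3,4-tetrahydronaphthalen-6-yl on an oxygen on a saturated carbon. Going by the values given here, the only measured step at this place, a number 64 percentage points higher from compound 1 to compound 3 (beyond the scatter), concerns the entry of the larger 4-phenylphenyl group, and it gives no direct guide to the smaller phenyl. Compound 2, which also carries phenoxy, though with a differently shaped core, gives -11% in this assay, a low number. Compound 4 is therefore expected to show no step beyond the scatter, estimated as no change at the digits printed from compound 1 to compound 4 (within the scatter). Compound 4 is expected to give 0% in this assay, within a range of -15% to 15%.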

Compound 4, a percentage reported as inhibition, at one concentration (the size of the read-out at that concentration, not a potency): -9%
Estimate against measurement, compound 4: 9 percentage points above, within the range that was stated.
By their numbers in this assay, from the lowest: compounds 2, 4 and 1 (each within the scatter of the next, the first and the last beyond it); then compound 3.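

In this assay, phenyl and 1,2,3,4-tetrahydronaphthalen-6-yl on this oxygen cannot be told apart, with a number 9 percentage points lower from compound 1 to compound 4 (within the scatter). Hydrogen in place of phenyl on an aromatic carbon, however, gives a number 73 percentage points lower from compound 3 to compound 4 (beyond the scatter), so among these compounds only the 4-phenylphenyl group goes with a high number. The drawn configuration at the saturated ring carbon also leaves the two phenyl compounds within the scatter, with a number 2 percentage points higher from compound 2 to compound 4 (within the scatter), and this comparison involves no other change: the fact that compounds 2 and 4 differ only in the configuration as drawn

As far as these compounds go, it remains open whether a cyclohexyl ring or an amine in place of the outer phenyl would keep the high number. The compounds shown also leave open whether the same configuration change would matter with the 4-phenylphenyl group present.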